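A Chlorine-Bearing Pyridine Replaces a Methylpyridine

The compounds below may be only part of what the source reports. "The series", "measured", "known", "first", "only" and "open" are said of these compounds alone.

Measured so far in a physicochemical assay for lipophilicity, read by LC-MS, in phosphate buffer, measured as octanol-water partition, with a stated time of 30 min, at pH 7.4, tested at 200 mM; a lower number here means a more polar compound, a higher number a more lipophilic compound:
- compound 1 `Cc1ccc(Oc2ccc3nc(COc4cccc(C(=O)O)c4)n(C)c3n2)cc1` gives 1.7
- compound 2 `Cn1c(COc2cccc(C(=O)O)c2)nc2cnc(Oc3ccc4c(c3)OCC4)cc21` gives 0.6
- compound 3 `Cc1cccc(Oc2ccc3nc(COc4cccc(C(=O)O)c4)n(C)c3c2)n1` gives 0.8

All three share a core carrying a benzoic acid through an ether link, and differ in the aryl group attached through the other ether oxygen. Among the three numbers, compound 3 stands second highest. Its nearest neighbour is compound 2, whose number lies lower by an amount that stays within the scatter, so the two cannot be told apart. Its furthest neighbour is compound 1, whose number lies higher by an amount beyond the scatter.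

Compound 4 `Cc1cc(Cl)cnc1Oc1ccc2nc(COc3cccc(C(=O)O)c3)n(C)c2c1` has not yet been measured in this assay. It differs from compound 3 in one place: 5-chloro-3-methylpyridin-2-yl in place of 6-methylpyridin-2-yl on an oxygen on an aromatic ring. Among the compounds with values here, no measured pair shows this change, so any expectation rests on the change itself. In this assay the step from compound 3 to compound 4 is expected to be upward by a number 0.70 log units higher from compound 3 to compound 4 (beyond the scatter). Compound 4 is therefore estimated at 1.5, within a range from 1 to 2.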

Compound 4, distribution coefficient: 1.8
Compound 4: middle estimate off by 0.30 log units, on the low side; low and high end bracket the measured number.
By their numbers in this assay, from the lowest: compounds 2 and 3 (each within the scatter of the next); then compounds 1 and 4 (each within the scatter of the next).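

In this assay, the group on this oxygen can shift the number well beyond the usual scatter: the step of a number 1.00 log units higher from compound 3 to compound 4 (beyond the scatter) comes with 5-chloro-3-methylpyridin-2-yl in place of 6-methylpyridin-2-yl. Within the data shown here, no earlier pair differed in only one place, so this is the first direct reading of a change at this position. Nothing measured here explains the size or direction of the step.

The entering group carries a chlorine and also has its methyl at a different numbered place on the pyridine, and this single step cannot show how much each of these two differences contributes. It also leaves open whether a fluorine or a nitrile in place of the chlorine would give a step of similar size.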